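The source may hold more compounds than are shown below. What is called first, only, known or untested is meant among the compounds shown, and "the series" means these compounds.

The shared core is seen in compound 1 `c1ccc(-c2ccc3[nH]ncc3c2)cc1`, which carries a phenyl group bearing no further substituent. In an assay on CHO-TREX cells for antagonist activity at transient receptor potential cation channel subfamily A member 1 (Homo sapiens), read by FLIPR and calcium flux, with a stated time of 10 min (a higher number here means a weaker inhibitor, a lower number a stronger inhibitor), compound 1 gives only a limit, > 30000 nM, and this is the limit of > 30000 nM in this assay, at which 1 of the 2 values shown sits. For the measured compounds named here, compound 2 `FC(F)(F)c1ccccc1-c1ccc2[nH]ncc2c1` carries a trifluoromethyl group on that phenyl ring, and in this assay compound 2 gives 164 nM, the only real number among the values shown. Going by the values given here, the one measured step, an at least 180-fold lower number from compound 1 to compound 2 (2.26 log units; beyond the scatter), is large.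

Compound 3 `Fc1cccc(-c2ccc3[nH]ncc3c2)c1C(F)(F)F` differs from compound 2 by fluoro in place of hydrogen on an aromatic carbon. Among the compounds with values here, the single measured step bears only loosely on this change, since it concerned a different group entering an unsubstituted ring, so it offers no direct guide to the size of the new step. Compound 3 is therefore expected to shift by about a 1.4-fold lower number from compound 2 to compound 3 (0.14 log units; within the scatter), a step judged to stay within the scatter. Compound 3 is estimated at 120 nM, with a range from 40 nM to 400 nM.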

Compound 3, half-maximal inhibitory concentration: 8900 nM
Estimate against measurement, compound 3: 74-fold (1.87 log units) below; measured number outside the range, above it.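

A single fluoro on an aromatic carbon ortho to a trifluoromethyl group is far from a silent change in this assay: it gives a 54-fold higher number from compound 2 to compound 3 (1.73 log units; beyond the scatter). The earlier compounds had shown only what trifluoromethyl does on entering the phenyl ring, whereas this step shows that the number also depends strongly on what occupies this neighbouring carbon, even when only one heavy atom replaces hydrogen. Compound 1 remains the only compound held at a limit of the assay rather than a number: the limit of > 30000 nM in this assay, at which 1 of the 3 values shown sits.

Whether the step is particular to fluoro stays open, as hydrogen and fluoro are the only substituents shown on this carbon, and a chloro, methyl or methoxy group there would help to separate the two cases. As far as these compounds go, it is also open whether fluoro would have a similar effect on a phenyl ring without the trifluoromethyl group.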